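A few compounds are considered here, and "the series" means these few. Any claim that something is new, unique, unknown or untested is made for them only; others in the source may bear on it.

Measured so far in a functional assay for agonist activity at G protein-coupled receptor 88 (Homo sapiens), read by HTRF and cAMP accumulation; on this read-out lower numbers stand for an effect already at smaller amounts and higher numbers for an effect only at larger amounts of compound:
compound 1 `CC[C@H](C)[C@H](N)CN(C(=O)[C@@H]1C[C@H]1C1CCCCC1)c1ccc(-c2ccccc2)cc1`: > 25000 nM
compound 2 `CC(C)C[C@H](N)CN(C(=O)[C@@H]1C[C@H]1c1ccccc1)c1ccc(-c2ccsc2)cc1`: 1200 nM

Compound 1 gives only a limit in this assay, namely > 25000 nM. Compound 2 stands as the single number shown in this assay, at 1200 nM. Among the measured compounds shown here, the one further value shown, that of compound 1, is a limit, (the limit of > 25000 nM in this assay, at which 1 of the 2 values shown sits). Compound 3 `CC(C)C[C@H](N)CN(C(=O)[C@@H]1C[C@H]1c1ccccc1)c1ccc(-c2ccc(C#N)cc2)cc1` differs from compound 2 in one place: 4-cyanophenyl in place of thiophen-3-yl on an aromatic carbon. For the measured compounds named here, no step between measured compounds is available to calibrate this change. The step from compound 2 to compound 3 is expected to be small, a 1.7-fold higher number from compound 2 to compound 3 (0.22 log units; within the scatter), leaning if anything toward an effect only at larger amounts. Compound 3 is estimated at 2000 nM, with a range from 600 nM to 8000 nM.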

Compound 3, half-maximal effective concentration: 670 nM
Beside the measured number, compound 3's estimate is 3.0-fold (0.47 log units) above it, within the range that was stated.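

In this assay, among the compounds shown here, 4-cyanophenyl in place of thiophen-3-yl gives a 1.8-fold lower number from compound 2 to compound 3 (0.25 log units; within the scatter) as the first one-place step. At this aromatic carbon, a five-membered aromatic ring with a sulfur atom and a six-membered carbon ring bearing a nitrile therefore read alike, with 5 and 8 heavy atoms respectively counted for the two groups. Nothing shown accounts for this likeness.

Still open, as far as these compounds go, is whether an amine or a carboxylic acid in place of the nitrile would read the same. Also open, from the compounds shown here alone, is whether a saturated group such as cyclohexyl could stand at this aromatic carbon.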